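Methoxy for chloro on the aryl ring of compound 1

A few compounds are considered here, and "the series" means these few. Any claim that something is new, unique, unknown or untested is made for them only; others in the source may bear on it.

Compound 1 `COc1cc(/C=C/C(=O)c2cccc(-n3cc(-c4ccc(Cl)cc4)[nH]c3=O)c2)cc(OC)c1OC` and compound 2 `O=C(/C=C/c1cccc(O)c1)c1cccc(-n2cc(-c3ccc(Cl)cc3)[nH]c2=O)c1` share the same core and differ from each other in more than one place. For the measured compounds named here, in a functional assay on U-251 cells (Homo sapiens) for inhibition (a lower number here means a stronger inhibitor of growth, a higher number a weaker inhibitor of growth), compound 1 gives 2120 nM, the highest of the two numbers measured so far. Going by the values given here, compound 2 gives 580 nM in this assay, a lower number beyond the scatter; as the two structures differ in several places at once, these two values show only that compound 2 sits lower, and the gap cannot be assigned to any single group.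

Compound 3 `COc1ccc(-c2cn(-c3cccc(C(=O)/C=C/c4cc(OC)c(OC)c(OC)c4)c3)c(=O)[nH]2)cc1` is the single-point change from compound 1: methoxy in place of chloro on an aromatic carbon. Among the compounds with values here, no measured pair shows this exchange, so there is nothing to size the step from directly. The expectation is that the methoxy in place of chloro leaves the number close to that of compound 1, with no step beyond the scatter in either direction, as the estimated step of a 1.1-fold lower number from compound 1 to compound 3 (0.03 log units; within the scatter) expresses. Compound 3 is therefore expected to give about 2000 nM in this assay, with a range from 700 nM to 6000 nM.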

Compound 3, concentration for 50% growth inhibition: 880 nM
The estimate for compound 3 lay 2.3-fold (0.36 log units) above the measured number, and the stated range covers the measured number.
By their numbers in this assay, from the lowest: compounds 2 and 3 (each within the scatter of the next); then compound 1.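

In this assay, for the compounds shown here, the change from 4-chlorophenyl to 4-methoxyphenyl gives a 2.4-fold lower number from compound 1 to compound 3 (0.38 log units; beyond the scatter), the first reading of a single exchange. The position para to a large group on this aromatic ring is therefore not indifferent to the substituent it carries: methoxy in place of chloro produces a modest step beyond the scatter, with the rest of compound 1 held constant. Nothing available bears on the origin of this step, so it stands only as an observed difference in growth inhibition.

A single pair cannot show whether the step is particular to methoxy or extends to other groups at the same place, such as fluoro, ethoxy or dimethylamino. Equally open, on these data alone, is whether methoxy in place of chloro would give a step of similar size and direction on the background of compound 2, where the other end of the molecule differs from that of compound 1.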